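Trimming Cyclohexyl to Methyl in an Integrin Antagonist Series

The source may hold more compounds than are shown below. What is called first, only, known or untested is meant among the compounds shown, and "the series" means these compounds.

Measured compounds:
compound 1, `C/C=C(\C(=O)O)C(NCc1ccc(N)cc1)C1CCCCC1`, 2100 nM
compound 2, `C/C=C1\C(=O)N(CC(=O)O)C(=O)N(Cc2ccc(NC(=O)CN)cc2)C1C(C)C`, > 100000 nM

Among the compounds with values here, in an assay on a protein complex (K562 cells) for inhibition of integrin alpha-5/beta-1 (Homo sapiens), with stated times of 30 min and 1 h (a lower number here means a stronger inhibitor, a higher number a weaker inhibitor), compound 1 gives 2100 nM, the only plain number recorded here. Compound 2 reaches only (the limit of > 100000 nM in this assay, at which 1 of the 2 values shown sits), which is a limit of the assay and not a number. Compound 3, `C/C=C(\C(=O)O)C(C)NCc1ccc(N)cc1`, differs from compound 1 by methyl in place of cyclohexyl on a saturated chain carbon bound to an amine nitrogen and a double-bonded chain carbon. Within the data shown here, no measured pair covers this change, so any prediction rests on compound 1 alone. Removing most of the group at that carbon is expected to weaken inhibition by a step clearly beyond the usual scatter. Compound 3 is therefore estimated at 15000 nM, with a range from 4000 nM to 60000 nM. The step expected is a 7.1-fold higher number from compound 1 to compound 3 (0.85 log units; beyond the scatter).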

Compound 3, half-maximal inhibitory concentration: 19 nM
For compound 3 the middle estimate is 790-fold (2.90 log units) above the measured one; measured number outside the range, below it.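

In this assay, the group on a saturated chain carbon bound to an amine nitrogen and a double-bonded chain carbon strongly governs inhibition: methyl in place of cyclohexyl gives a 110-fold lower number from compound 1 to compound 3 (2.04 log units; beyond the scatter) in the shared core. Cyclohexyl is therefore not required at this position for inhibition of the integrin. Nothing shown explains this gain. The compounds shown leave open how hydrogen, ethyl or a longer chain at this carbon would compare with methyl, and whether the gain would persist with an ester in place of the carboxylic acid.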